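The source may report more compounds than this note shows. Statements on the series, on what has been measured and on what is new or still open speak of the compounds shown alone.

Measured in a functional assay on ECa-109 cells for antiproliferative activity against ECa-109 cell line (Homo sapiens), read by MTT assay, with a stated time of 72 h; on this read-out higher numbers stand for weaker inhibition and lower numbers for stronger inhibition:
- compound 1 `C/C(=N\NC(=O)c1cccc(S(=O)(=O)N2CCOCC2)c1)c1cc(O)ccc1O`: 21400 nM
- compound 2 `O=C(N/N=C/c1ccco1)c1cccc(S(=O)(=O)N2CCOCC2)c1`: > 100000 nM (a limit, not a number)

Going by the values given here, only two compounds have been tested here, and only one of them has a true number. Compound 2 gives > 100000 nM, which is a limit of the assay and not a number.

The next compound to be tested is compound 3 `O=C(N/N=C/c1cc(Br)ccc1O)c1cccc(S(=O)(=O)N2CCOCC2)c1`. It keeps the shared core but has 5-bromo-2-hydroxyphenyl in place of furan-2-yl on a carbon with a double bond to nitrogen.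

Among the compounds with values here, no measured step exists to guide a prediction, so the expectation rests on compound 1, which gives 21400 nM. A clear move towards stronger inhibition in this assay is expected, an estimated at least 6.6-fold lower number from compound 2 to compound 3 (0.82 log units; beyond the scatter). For compound 3 the estimated value is 15000 nM, with an expected range of 4000 nM to 60000 nM.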

Compound 3, half-maximal inhibitory concentration: 11700 nM
Compound 3: the middle estimate sits 1.3-fold (0.11 log units) above what was measured, within the range that was stated.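

In this assay, placing 5-bromo-2-hydroxyphenyl in place of furan-2-yl on a carbon with a double bond to nitrogen gives an at least 8.5-fold lower number from compound 2 to compound 3 (0.93 log units; beyond the scatter), so the group at this position can decide whether the series gives a measurable value at all. The change replaces a five-membered aromatic ring with one hetero atom by a six-membered aromatic ring of carbon only, and it adds a bromine and a hydrogen-bond donor. The true size of the step remains unknown, because compound 2 gives only a limit and not a number: the limit of > 100000 nM in this assay, at which 1 of the 3 values shown sits.

Since several features change together, the compounds shown cannot tell whether the bromine, the hydroxyl or the six-membered ring matters most. From the compounds shown here alone, it also remains open how a plain phenyl, a chlorine in place of the bromine, or an amine in place of the hydroxyl would behave.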